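Ethoxycarbonylethenyl for propylcarbamoyl on the shared core

The compounds below may be only part of what the source reports. "The series", "measured", "known", "first", "only" and "open" are said of these compounds alone.

Compound 1 `CCCOC(=O)c1ccc(-c2nn(Cc3ccccc3)c3ccccc23)cc1`: in a functional assay on cells (Platelet, Homo sapiens) for inhibition (on this read-out higher numbers stand for weaker inhibition and lower numbers for stronger inhibition), compound 1 gives only a limit, > 10000 nM.
Compound 2 `CCNC(=O)c1ccc(-c2nn(Cc3ccccc3)c3ccccc23)cc1`: in this assay compound 2 gives only a limit, > 10000 nM.
Compound 3 `CCCNC(=O)c1ccc(-c2nn(Cc3ccccc3)c3ccccc23)cc1`: in this assay compound 3 gives only a limit, > 10000 nM.

Compound 3 therefore stands nowhere in particular on the numbers: its value is a limit, and no number separates it from the other two. The steps a step that the two limits leave unreadable from compound 1 to compound 2, a step that the two limits leave unreadable from compound 1 to compound 3 and a step that the two limits leave unreadable from compound 2 to compound 3 stay unreadable because of the limit of > 10000 nM in this assay, at which 3 of the 3 values shown sit. Compound 4 `CCOC(=O)/C=C/c1ccc(-c2nn(Cc3ccccc3)c3ccccc23)cc1` differs from compound 3 by 2-(ethoxycarbonyl)ethenyl in place of propylcarbamoyl on an aromatic carbon. Among the measured compounds shown here, none of the measured steps bears directly on this change; they show only that swapping the propoxy ester for two amides, and lengthening the amide chain, kept every value at the limit. No readable step supports a direction, so the expected step that the limit leaves unreadable from compound 3 to compound 4 is taken as none beyond the scatter, with the outcome most likely another limit. For compound 4 the estimate in this assay is 12000 nM, with a range from 3000 nM to 50000 nM.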

Compound 4, half-maximal inhibitory concentration: > 10000 nM
Compound 4 was reported as a limit; the forecaster's own chance of this, stated with the estimate: 75%; the middle value is on the limit's open side.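

In this assay compound 4 gives > 10000 nM as a limit. Among the compounds shown here, no step from compound 1, compound 2 or compound 3 to compound 4 can be read, because all four compounds sit at the same limit: (the limit of > 10000 nM in this assay, at which 4 of the 4 values shown sit). The compounds shown leave open whether any change on the shared core gives a measurable value in this assay at all.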